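The source may hold more compounds than are shown below. What is called first, only, known or untested is meant among the compounds shown, and "the series" means these compounds.

Three compounds have been measured in an ADME assay on HepG2 cells (Homo sapiens) for cytotoxicity, read by luminescence, CellTiter-Glo and ATP content, with a stated time of 72 h; a higher number here means that more compound is needed for the effect, a lower number that less compound is needed:

Compound 1 `COc1ccc(F)cc1CNCCCNc1ccnc2cc(Cc3cc(C)cc(C)c3)ccc12` gives 940 nM.
Compound 2 `COc1cccc(CNCCCNc2ccnc3cc(Oc4ccc(Cl)cc4)ccc23)c1O` gives 5700 nM.
Compound 3 `COc1ccc(F)cc1CNCCCNc1ccnc2cc(CC(C)C)ccc12` gives 2900 nM.

Compound 2 shows the highest number of the three, which in this assay means that the most compound is needed to harm the cells. Its number and that of compound 3 sit within the usual scatter of each other, so they cannot be told apart; compound 1 sits clearly lower than compound 2.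

The new compound 4 `COc1cccc(CNCCCNc2ccnc3cc(-c4ccccc4)ccc23)c1O` differs from compound 2 in one place: phenyl in place of 4-chlorophenoxy on an aromatic carbon. Within the data shown here, the only measured step, a 3.1-fold higher number from compound 1 to compound 3 (0.49 log units; beyond the scatter), concerns the same aromatic carbon of the core but a different kind of change, an aromatic group giving way to a saturated one, and it was modest. In compound 4 an aromatic ring remains at that position, only without the oxygen link and the chlorine. Among the measured compounds shown here, no measured pair shows this kind of exchange. The step from compound 2 to compound 4 in this assay is therefore expected to be small, perhaps a slight rise, and likely within the scatter, as a 1.1-fold higher number from compound 2 to compound 4 (0.06 log units; within the scatter).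

Compound 4 is estimated to give 6500 nM in this assay, with a range from 2200 nM to 19000 nM.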

Compound 4, half-maximal effective concentration: 3210 nM
Compound 4: the middle estimate sits 2.0-fold (0.31 log units) above what was measured; measured number inside the range.
By their numbers in this assay, from the lowest: compound 1; then compounds 3, 4 and 2 (each within the scatter of the next).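

In this assay, among these compounds, the first direct exchange of one ring-bearing group for another on this aromatic carbon of the shared core, phenyl in place of 4-chlorophenoxy, gives a 1.8-fold lower number from compound 2 to compound 4 (0.25 log units; within the scatter). The earlier step at this carbon, a 3.1-fold higher number from compound 1 to compound 3 (0.49 log units; beyond the scatter), put a group without a ring in place of one with a ring, so it could not show what happens when an aromatic ring stays and only its surroundings change. Here the oxygen link and the chlorine both leave, taking the group from 8 heavy atoms to 6 and removing its one hydrogen-bond acceptor, yet the two compounds cannot be told apart in this assay, and nothing measured here gives a reason for that.

From the compounds shown here alone, both the oxygen link and the chlorine left in a single exchange, so their separate contributions remain unknown, and phenoxy or 4-chlorophenyl on this carbon would be needed to pull them apart. Going by these compounds, it is also open how this side chain and core would respond to a group of a different kind at the same carbon, such as an amine or a carboxylic acid.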